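From 2-methoxyphenyl back to a small alkyl group

The compounds below may be only part of what the source reports. "The series", "measured", "known", "first", "only" and "open" are said of these compounds alone.

Compound 1 `CCCCCc1ccc(-c2cn(C/C=C3\OC(=O)C(OCc4ccccc4)=C3OCc3ccccc3)nn2)cc1` gives > 100000 nM
Compound 2 `CCCCc1cn(C[C@H](O)[C@H]2OC(=O)C(OCc3ccccc3)=C2OCc2ccccc2)nn1` gives 47500 nM
Compound 3 `COc1ccccc1-c1cn(C[C@H](O)[C@H]2OC(=O)C(OCc3ccccc3)=C2OCc2ccccc2)nn1` gives > 100000 nM

These values come from a functional assay on SW-620 cells (Homo sapiens) for antiproliferative activity, read by MTT assay, with a stated time of 72 h (a lower number here means a stronger inhibitor, a higher number a weaker inhibitor), and the three compounds are the whole of the evidence so far. Compound 3 gives > 100000 nM and this is a limit of the assay, not a number. Compound 1 gives > 100000 nM and this is a limit too. Together they make up the limit of > 100000 nM in this assay, at which 2 of the 3 values shown sit, and so compound 3 has no exact place in the series. For the measured compounds named here, compound 2 gives 47500 nM as the only true number.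

The next compound is compound 4 `CC(C)(C)c1cn(C[C@H](O)[C@H]2OC(=O)C(OCc3ccccc3)=C2OCc2ccccc2)nn1` and it carries tert-butyl in place of 2-methoxyphenyl on an aromatic carbon with the rest of compound 3 unchanged.

Going by the values given here, one measured step bears on this change. It is an at least 2.1-fold higher number from compound 2 to compound 3 (0.32 log units; beyond the scatter) for 2-methoxyphenyl in place of butyl. Leaving 2-methoxyphenyl for tert-butyl runs the opposite way, and tert-butyl is a branched form of butyl, so a lower number is expected, though it may still reach the limit. The expected change is an at least 1.6-fold lower number from compound 3 to compound 4 (0.22 log units; that floor lies within the scatter) and this remains a rough estimate. In this assay the expected value for compound 4 is 60000 nM within an estimated range of 30000 nM to 120000 nM on this reasoning.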

Compound 4, half-maximal inhibitory concentration: 35800 nM
Beside the measured number, compound 4's estimate is 1.7-fold (0.22 log units) above it; measured number inside the range.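

In this assay there is an at least 2.7-fold lower number from compound 3 to compound 4 (0.44 log units; beyond the scatter) when tert-butyl takes the place of 2-methoxyphenyl on this aromatic carbon of the five-membered ring, so a small alkyl group here brings back a measurable value. Branching the four-carbon group makes no readable difference, since there is a 1.3-fold lower number from compound 2 to compound 4 (0.12 log units; within the scatter), and butyl and tert-butyl therefore cannot be told apart at this position. The first of these steps gives only a minimum size, because compound 3 sits at a limit and has no exact value: the limit of > 100000 nM in this assay, at which 2 of the 4 values shown sit.

For the compounds shown here, with only two alkyl groups and one substituted aromatic ring at this position, it stays open whether the ring itself or its methoxy group goes with the loss of a measurable value, and a plain phenyl group would separate the two. On these data alone, it is equally open how the value would respond to a much smaller group such as methyl, a longer chain such as octyl, or a chain ending in an amine or a carboxylic acid.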